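A few compounds are considered here, and "the series" means these few. Any claim that something is new, unique, unknown or untested is made for them only; others in the source may bear on it.

Compound 1 `CCCCCCc1ccc(-c2c(C)[nH]c(=O)n2C)cc1`: 9000 nM
Compound 2 `CCCCCCOc1ccc(-c2c(C)[nH]c(=O)n2C)cc1`: 7300 nM

These two compounds have been measured in a functional assay on brain (Rattus norvegicus, strain Wistar) for inhibition; on this read-out higher numbers stand for weaker inhibition and lower numbers for stronger inhibition. Compound 2 gives 7300 nM, the lower of the two numbers, but the gap to compound 1 does not exceed the usual scatter of such measurements, so neither can be ranked above the other.

The next compound, compound 3 `Cc1[nH]c(=O)n(C)c1-c1ccc(C2CCCCC2)cc1`, keeps the shared core and changes one group: cyclohexyl in place of hexyloxy on an aromatic carbon.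

For the measured compounds named here, only one measured step bears on this change: a 1.2-fold lower number from compound 1 to compound 2 (0.09 log units; within the scatter). Going by the values given here, it exchanges hexyl for hexyloxy, and no compound with a ring in that place has been measured, so it is only a loose guide. With that single small step to go on, little movement is expected, and the direction is uncertain.

The expected step is a 1.2-fold higher number from compound 2 to compound 3 (0.09 log units; within the scatter).

For compound 3 the estimated value is 9000 nM, with an expected range from 3500 nM to 25000 nM.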

Compound 3, half-maximal inhibitory concentration: 10000 nM
Beside the measured number, compound 3's estimate is 1.1-fold (0.05 log units) below it; measured number inside the range.
By their numbers in this assay, from the lowest: compounds 2, 1 and 3 (each within the scatter of the next).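

In this assay, replacing either open chain with a ring at this aromatic carbon gives only small steps: a 1.4-fold higher number from compound 2 to compound 3 (0.14 log units; within the scatter), and a 1.1-fold higher number from compound 1 to compound 3 (0.05 log units; within the scatter). Both steps lie within the scatter, so hexyl, hexyloxy and cyclohexyl cannot be told apart at this position. This extends the earlier comparison of two open chains to a group with one six-membered non-aromatic ring of carbon only, and neither adding that ring nor losing the oxygen of hexyloxy gives a readable difference, though no measured evidence explains why these groups read alike.

The compounds shown leave open whether any group at this position can move the number beyond the scatter, such as an amine, a carboxylic acid or a much shorter chain like methyl. Going by these compounds, the effect of changes elsewhere on the shared core also remains open.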